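From 3,5-dimethylphenyl to 3-chlorophenyl on a sulfonamide nitrogen

This account rests on a few compounds, and the source may have more. Where it says the series, first, only, none or still open, it means among the compounds named here.

Values so far in a functional assay on MCF7 cells (Homo sapiens) for antiproliferative activity, read by sulforhodamine B assay, with a stated time of 48 h (on this read-out higher numbers stand for weaker inhibition and lower numbers for stronger inhibition), are as follows:
- compound 1 `CCc1ccccc1NS(=O)(=O)c1ccc(N2CCNC2=O)cc1` gives 350 nM
- compound 2 `O=C1NCCN1c1ccc(S(=O)(=O)Nc2ccc(F)c(F)c2)cc1` gives 620 nM
- compound 3 `Cc1cc(C)cc(NS(=O)(=O)c2ccc(N3CCNC3=O)cc2)c1` gives 100 nM

Compound 3 holds the lowest number of the three, which makes it the strongest inhibitor here. Still unmeasured is compound 4 `O=C1NCCN1c1ccc(S(=O)(=O)Nc2cccc(Cl)c2)cc1`, which carries 3-chlorophenyl in place of 3,5-dimethylphenyl on a sulfonamide nitrogen and keeps the shared core.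

Three measured changes at this same place bear on it. Two of them end at the 3,5-dimethylphenyl group: a 3.5-fold lower number from compound 1 to compound 3 (0.54 log units; beyond the scatter) and a 6.2-fold lower number from compound 2 to compound 3 (0.79 log units; beyond the scatter) are both modest. The third, a 1.8-fold higher number from compound 1 to compound 2 (0.25 log units; within the scatter), does not separate the other two groups. Neither of those groups matched compound 3, so leaving 3,5-dimethylphenyl is expected to give a modestly higher number in this assay, although three compounds are a thin basis. The expected change is a 2.5-fold higher number from compound 3 to compound 4 (0.40 log units; beyond the scatter) in this estimate. Compound 4 is expected at 250 nM with an estimated range of 80 nM to 700 nM once measured.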

Compound 4, half-maximal inhibitory concentration: 79 nM
Compound 4: middle estimate off by 3.2-fold (0.50 log units), on the high side; measured number outside the range, below it.
By their numbers in this assay, from the lowest: compounds 4 and 3 (each within the scatter of the next); then compounds 1 and 2 (each within the scatter of the next).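

In this assay, 3-chlorophenyl on the sulfonamide nitrogen stands level with 3,5-dimethylphenyl, with a 1.3-fold lower number from compound 3 to compound 4 (0.10 log units; within the scatter), so the low numbers at this position no longer rest on a single group. The separation from the other two groups holds as well, with a 7.8-fold lower number from compound 2 to compound 4 (0.89 log units; beyond the scatter) and a 4.4-fold lower number from compound 1 to compound 4 (0.65 log units; beyond the scatter). Compound 2 also carries halogen atoms on its ring, so among these compounds a halogen alone does not bring a low number, since the 3,4-difluorophenyl group stays with the 2-ethylphenyl group at the higher end.

No measurement at hand accounts for these differences. Also open is what a phenyl ring bearing an amine or a carboxylic acid would give on this nitrogen, since the four groups shown carry only alkyl or halogen substituents.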